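Moving a Carbamoyl Group Along a Phenylethyl Amide

The compounds below may be only part of what the source reports. "The series", "measured", "known", "first", "only" and "open" are said of these compounds alone.

Compound 1 `N=C(N)NCCCN(CC(=O)N[C@@H](CCCCN)C(=O)N[C@@H](C(N)=O)c1ccccc1)C(=O)c1ccccc1`: <= 5%
Compound 2 `CC(NC(=O)[C@H](CCCCN)NC(=O)[C@H](CCCNC(=N)N)NC(=O)c1ccccc1)(C(N)=O)c1ccccc1`: <= 5%
Compound 3 `N=C(N)NCCC[C@H](NC(=O)c1ccccc1)C(=O)N[C@@H](CCCCN)CC(=O)N[C@@H](C(N)=O)c1ccccc1`: <= 5%

In an assay on isolated protein for inhibition of Trypsin (Homo sapiens), read by fluorescence, with a stated time of 15 min, tested at 50 uM (on this read-out higher numbers stand for more inhibition at the one concentration tested (going by the name of the read-out) and lower numbers for less inhibition), compound 1 gives <= 5%, which is a limit of the assay and not a number. Compound 2 gives <= 5%, again a limit. Compound 3 likewise gives <= 5%, a limit. So compound 2 stands where every measured compound stands, at the limit of <= 5% in this assay, at which 3 of the 3 values shown sit, and no measured pair differs in a single place from which a step could be read.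

Compound 4 `N=C(N)NCCC[C@H](NC(=O)c1ccccc1)C(=O)N[C@@H](CCCCN)C(=O)N[C@@H](CC(N)=O)c1ccccc1` has the same atoms as compound 2, joined differently: 2-carbamoyl-1-phenylethyl in place of 1-carbamoyl-1-phenylethyl on an amide-type nitrogen. With all three measured values at the limit, nothing points to a shift beyond the scatter. Compound 4 is therefore expected at 3%, between 0% and 15%, an estimated step that the limit leaves unreadable from compound 2 to compound 4.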

Compound 4, a percentage reported as inhibition, at one concentration (the size of the read-out at that concentration, not a potency): 7.5%
Compound 4: the middle estimate sits 4.5 percentage points below what was measured, and the stated range covers the measured number.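

For the compounds shown here, compound 4, at 7.5%, is the first compound in this assay to give a number rather than a limit. Moving to 2-carbamoyl-1-phenylethyl in place of 1-carbamoyl-1-phenylethyl on an amide-type nitrogen gives a number at least 2.5 percentage points higher from compound 2 to compound 4 (that floor lies within the scatter), so this change shows no gain beyond the scatter. Compound 2 gives <= 5%, which is a limit of the assay, so the exact size of the step stays unknown: the limit of <= 5% in this assay, at which 3 of the 4 values shown sit.

On these data alone, what stays open is whether a carboxylic acid in place of the carbamoyl group would give clearly more inhibition. As far as these compounds go, the effect of a longer chain carrying the carbamoyl group is equally open.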